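The source may report more compounds than this note shows. Statements on the series, on what has been measured and on what is new or still open speak of the compounds shown alone.

Compound 1 `CCCCCCCCCCCCCCCCOP(=O)(O)OCCSC(=S)N1CCCCC1` is tested in a functional assay on MDA-MB-231 cells (Homo sapiens) for inhibition, read by MTT assay, with stated times of 18 h and 4 h (a higher number here means a weaker inhibitor, a lower number a stronger inhibitor), where compound 1 gives 100000 nM. Two related compounds have been measured alongside it: compound 2 `CCCCCCCCCCOP(=O)(O)OCCSC(=S)N1CCCC1`, which in this assay gives 67000 nM, and compound 3 `CCCCCCOP(=O)(O)OCCSC(=S)N1CCCC1`, which gives 54000 nM. On these numbers compound 1 stands highest of the three, but its gaps to compound 2 and to compound 3 both lie within the scatter, so no order among them can be read.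

The step now followed leads to compound 4 `CCCCCCCCOP(=O)(O)OCCSC(=S)N1CCCCC1`. The change from compound 1 is hydrogen in place of octyl on a saturated chain carbon, eight bonds along the chain from an oxygen on an unsaturated carbon. Going by the values given here, the one measured step of the same kind is the shortening of the chain between compound 2 and compound 3, which gave a 1.2-fold lower number from compound 2 to compound 3 (0.09 log units; within the scatter) and so no movement beyond the scatter. The shift from compound 1 to compound 2, also a chain shortening together with a change of the ring, likewise stayed within the scatter. On this basis the expected step in this assay is small, if anything towards a lower number, and is estimated as a 1.5-fold lower number from compound 1 to compound 4 (0.19 log units; within the scatter). Compound 4 is therefore expected to give about 65000 nM, within a range from 30000 nM to 140000 nM.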

Compound 4, half-maximal inhibitory concentration: 11900 nM
For compound 4 the middle estimate is 5.5-fold (0.74 log units) above the measured one, and the stated range ends above it.
By their numbers in this assay, from the lowest: compound 4; then compounds 3, 2 and 1 (each within the scatter of the next).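

In this assay, hydrogen in place of octyl, eight bonds along the chain from an oxygen on an unsaturated carbon, gives an 8.4-fold lower number from compound 1 to compound 4 (0.92 log units; beyond the scatter), the first shortening of the alkyl chain shown here to move beyond the scatter. The earlier step, with hydrogen in place of butyl on a different core, gave a 1.2-fold lower number from compound 2 to compound 3 (0.09 log units; within the scatter), so shortening the chain does not always leave the number unchanged, and at this position on the core of compound 1 the chain length does matter. Nothing measured here bears on why removing octyl has this effect.

With only these two steps, the compounds shown leave open whether the size of the shift follows the length of chain removed or the core that carries it, and where along the chain the change sets in, which a decyl or dodecyl chain on the core of compound 1 would help to place. They also leave open how this assay would respond to a chain ending in an amine or a carboxylic acid, or to a chain shorter than hexyl.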